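Replacing the hydroxyphenyl amine in a quinazoline series

The source may report more compounds than this note shows. Statements on the series, on what has been measured and on what is new or still open speak of the compounds shown alone.

Compound 2 — `Oc1cccc(Nc2nc(-c3cccc(F)c3)nc3ccc(F)cc23)c1` — a functional assay on HT29-AK cells (Homo sapiens) for cytotoxicity, read by MTT assay, with a stated time of 48 h; a lower number here means a stronger inhibitor, a higher number a weaker inhibitor: > 50000 nM
Compound 1 — `Fc1cccc(-c2nc(Nc3ccc(Br)cc3)c3cc(F)ccc3n2)c1` — this assay: > 50000 nM

In this assay compound 2 reaches only a limit of the assay, > 50000 nM. Compound 1, `Fc1cccc(-c2nc(Nc3ccc(Br)cc3)c3cc(F)ccc3n2)c1`, likewise stops at a limit, > 50000 nM. For the measured compounds named here, the one measured step, a step that the two limits leave unreadable from compound 1 to compound 2, therefore cannot be read, and the limit of > 50000 nM in this assay, at which 2 of the 2 values shown sit, is all the evidence on hand. Compound 3 is `Cc1ccccc1Nc1nc(-c2cccc(F)c2)nc2ccc(F)cc12`; its change is 2-methylphenyl in place of 3-hydroxyphenyl on a nitrogen on an aromatic ring. Nothing measured bears on this change, so compound 3 is expected to sit at the same limit, a step that the limit leaves unreadable from compound 2 to compound 3. Compound 3 is estimated at 60000 nM, between 15000 nM and 250000 nM.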

Compound 3, half-maximal inhibitory concentration: > 50000 nM
Compound 3: only a limit was reported (the forecaster's own chance of this, stated with the estimate: 80%); the middle value lies beyond the limit too.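

For the compounds shown here, compound 1, compound 2 and compound 3 all stop at a limit in this assay, so no step among them can be read. The compounds shown leave open whether any group on this nitrogen gives a readable value.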